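Adding a methyl to the phenyl of compound 2

A few compounds are considered here, and "the series" means these few. Any claim that something is new, unique, unknown or untested is made for them only; others in the source may bear on it.

Compound 1 (`Cc1ccc(S(=O)(=O)c2nc3ccccc3nc2N2CCCC2)cc1`) : > 50000 nM (a limit of the assay)
Compound 2 (`O=S(=O)(c1ccccc1)c1nc2ccccc2nc1N1CCCC(O)C1`) : 310 nM (a measured number)

Within the data shown here, in a functional assay on A549 cells (Homo sapiens) for cytotoxicity, read by MTT assay, with a stated time of 72 h (a lower number here means a stronger inhibitor, a higher number a weaker inhibitor), compound 2 gives 310 nM and holds the only actual number so far. Compound 1 reads > 50000 nM, which is a limit and not a number.

Compound 3 (`Cc1ccc(S(=O)(=O)c2nc3ccccc3nc2N2CCCC(O)C2)cc1`) differs from compound 2 in one place: methyl in place of hydrogen on an aromatic carbon (methyl in place of hydrogen on an aromatic carbon, phenyl to 4-methylphenyl). Among the measured compounds shown here, no measured pair isolates this change. For so small an addition, a slight weakening in this assay is expected, possibly none beyond the scatter. The estimated change is a 1.6-fold higher number from compound 2 to compound 3 (0.21 log units; within the scatter) as the expected step. For compound 3 the expected value is 500 nM, with an estimated range of 150 nM to 2500 nM.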

Compound 3, half-maximal inhibitory concentration: 1350 nM
Compound 3: middle estimate off by 2.7-fold (0.43 log units), on the low side; the measured number falls inside the stated range.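

In this assay, methyl in place of hydrogen on this aromatic carbon, para to a large group, is not a silent change: a 4.4-fold higher number from compound 2 to compound 3 (0.64 log units; beyond the scatter). With the 4-methylphenyl held fixed, 3-hydroxypiperidin-1-yl in place of pyrrolidin-1-yl gives an at least 37-fold lower number from compound 1 to compound 3 (1.56 log units; beyond the scatter), so the group at this second place has the larger reach of the two changes in this small set. The size of that step is bounded only, since compound 1 gives a limit and not a number: the limit of > 50000 nM in this assay, at which 1 of the 3 values shown sits.

The compounds shown leave open whether the hydroxyl or the change from pyrrolidin-1-yl to the piperidine ring carries that step, which plain piperidin-1-yl would separate. They also leave open whether a chlorine or a methoxy at the methyl's place would follow the methyl.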